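The compounds below may be only part of what the source reports. "The series", "measured", "known", "first", "only" and "open" are said of these compounds alone.

Values in a functional assay on Jurkat cells (Homo sapiens) for inhibition (a lower number here means a stronger inhibitor, a higher number a weaker inhibitor), for the measured members of the series:

- compound 1, `CC(C)[C@H](NC(=O)COc1cccc2ccccc12)C(=O)N[C@@H](CC(=O)O)C(=O)CSc1nnc(-c2ccccc2)o1`, gives 150000 nM.
- compound 2, `CC(C)[C@H](NC(=O)COc1cccc2ccccc12)C(=O)N[C@@H](CC(=O)O)C(=O)CSc1nnnn1-c1ccccc1`, gives 153000 nM.
- compound 3, `CC(C)[C@H](NC(=O)COc1cccc2ccccc12)C(=O)N[C@@H](CC(=O)O)C(=O)COc1nc2ccccc2[nH]1`, gives only a limit of the assay, > 200000 nM.

Compound 1 holds the lowest of the two numbers in this assay, with compound 2 nearest: a 1.0-fold higher number from compound 1 to compound 2 (0.01 log units; within the scatter), so the two cannot be told apart. Compound 3 returned no number; its result is recorded as the limit of > 200000 nM in this assay, at which 1 of the 3 values shown sits.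

Compound 4, `CC(C)[C@H](NC(=O)COc1cccc2ccccc12)C(=O)N[C@@H](CC(=O)O)C(=O)COc1nncc(Cl)c1Cl`, is the next step from compound 1: (4,5-dichloropyridazin-3-yl)oxy in place of (5-phenyl-1,3,4-oxadiazol-2-yl)sulfanyl on a saturated chain carbon bound to a carbonyl carbon. For the measured compounds named here, two measured steps bear on it. The move from the sulfanyl-linked group to an oxy-linked group ended at the assay limit in both cases: an at least 1.3-fold higher number from compound 1 to compound 3 (0.12 log units; that floor lies within the scatter) and an at least 1.3-fold higher number from compound 2 to compound 3 (0.11 log units; that floor lies within the scatter). Going by the values given here, none of the measured steps moved the number beyond the scatter, and the only oxy-linked analogue reached no number at all. Compound 4 is therefore expected to sit at or near that limit, a step of a 1.5-fold higher number from compound 1 to compound 4 (0.17 log units; within the scatter), with a fair chance that the assay again reports only a limit. The estimate for compound 4 in this assay is 220000 nM, with a range from 110000 nM to 450000 nM.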

Compound 4, half-maximal inhibitory concentration: > 200000 nM
Compound 4 was reported as a limit; the forecaster's own chance of this, stated with the estimate: 55%; the middle value lies beyond the limit too.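

With compound 4, the limit no longer rests on one oxy-linked group: (4,5-dichloropyridazin-3-yl)oxy on the saturated chain carbon bound to a carbonyl carbon joins (1H-benzimidazol-2-yl)oxy there, and in this assay compound 4 gives only a limit, > 200000 nM. Two different oxy-linked rings now end in the same place, one a six-membered aromatic ring with 2 hetero atoms and no phenyl group, so this outcome is not tied to the benzimidazole: the limit of > 200000 nM in this assay, at which 2 of the 4 values shown sit. Against the sulfanyl-linked compounds the readings are an at least 1.3-fold higher number from compound 1 to compound 4 (0.12 log units; that floor lies within the scatter) and an at least 1.3-fold higher number from compound 2 to compound 4 (0.11 log units; that floor lies within the scatter), so no separation beyond the scatter is shown, and the step between compound 3 and compound 4 cannot be read.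

The compounds shown do not separate the linking atom from the ring, and that question would need a matched pair such as (4,5-dichloropyridazin-3-yl)sulfanyl against compound 4, or (5-phenyl-1,3,4-oxadiazol-2-yl)oxy against compound 1. Compound 1 gives 150000 nM. Also open, going by these compounds, is whether any group at this place, for example 2,3,5,6-tetrafluorophenoxy, gives a clearly lower number.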